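Phenyl in place of chloro on compound 2

The source may hold more compounds than are shown below. What is called first, only, known or untested is meant among the compounds shown, and "the series" means these compounds.

Measured compounds:
compound 1 `CC1=NC(C)=C([N+](=O)[O-])C(c2cccc(C(F)(F)F)n2)/C1=C(/O)OCCc1ccccc1`: 1410 nM
compound 2 `CC1=NC(C)=C([N+](=O)[O-])C(c2cccc(Cl)n2)/C1=C(/O)OCCc1ccccc1`: 1510 nM
compound 3 `CC1=NC(C)=C([N+](=O)[O-])C(c2ncccc2Cl)/C1=C(/O)OCCc1ccccc1`: 5170 nM

In a functional assay (muscle tissue) with Cavia porcellus as the target (on this read-out higher numbers stand for weaker inhibition and lower numbers for stronger inhibition), compound 2 gives 1510 nM, the second highest of the three numbers. Compound 1 lies closest to it: the step of a 1.1-fold higher number from compound 1 to compound 2 (0.03 log units; within the scatter) is within the scatter, so the two cannot be told apart on this read-out. Compound 3 lies furthest away, with a 3.4-fold higher number from compound 2 to compound 3 (0.53 log units; beyond the scatter), and compound 1 shows the same picture in a 3.7-fold higher number from compound 1 to compound 3 (0.56 log units; beyond the scatter).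

Compound 4 `CC1=NC(C)=C([N+](=O)[O-])C(c2cccc(-c3ccccc3)n2)/C1=C(/O)OCCc1ccccc1` is not yet measured. It differs from compound 2 in one place: phenyl in place of chloro on an aromatic carbon.

Two kinds of measured step bear on this change. The step from compound 1 to compound 2 exchanges one group for another on the same aromatic carbon and stays within the scatter. The steps to compound 3 show that placing the chloro on a different carbon weakens inhibition modestly. Within the data shown here, neither step brings in a ring, so the new change has no close measured counterpart. The expectation is a small step, a 1.3-fold higher number from compound 2 to compound 4 (0.12 log units; within the scatter), in this assay, with a wide range to cover the lack of a direct precedent.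

Compound 4 is therefore estimated at 2000 nM, with a range from 600 nM to 7000 nM.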

Compound 4, half-maximal inhibitory concentration: 8380 nM
For compound 4 the middle estimate is 4.2-fold (0.62 log units) below the measured one; measured number outside the range, above it.
By their numbers in this assay, from the lowest: compounds 1 and 2 (each within the scatter of the next); then compounds 3 and 4 (each within the scatter of the next).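

In this assay, among these compounds, the aromatic carbon next to the ring nitrogen had so far held chloro and trifluoromethyl with no step beyond the scatter, so it could have seemed indifferent to what sits there. Phenyl ends that picture, with a 5.5-fold higher number from compound 2 to compound 4 (0.74 log units; beyond the scatter) and with a 5.9-fold higher number from compound 1 to compound 4 (0.77 log units; beyond the scatter) as well, and on this read-out both steps mean weaker inhibition. The change puts 6 heavy atoms and a six-membered aromatic ring where chloro has 1 heavy atom and no ring, which shows that this position does respond to the group it carries, though no measurement shown here gives a reason for the loss.

Phenyl adds atoms and a ring in a single change, so these compounds cannot say which of the two matters, and a non-aromatic ring such as cyclohexyl or an open chain such as n-butyl on the same carbon would help separate them. Going by these compounds, whether a ring bearing nitrogen, such as pyridyl, or a small group such as methoxy or an amine would keep the level of compound 2 also remains open.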